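The compounds below may be only part of what the source reports. "The series", "measured", "known", "first", "only" and "open" are said of these compounds alone.

Working notes on the series. Two compounds have been run in an ADME assay on HCT-116 cells (Homo sapiens) for cytotoxicity, read by CellTiter-Glo, with a stated time of 72 h (on this read-out higher numbers stand for weaker inhibition and lower numbers for stronger inhibition), so far. Compound 1 `CC1CCN(C2CCN(S(=O)(=O)c3ccc(-c4ccccc4F)cc3)CC2)CC1` carries a 2-fluorophenyl on an aromatic carbon of its core, para to a large group. In this assay compound 1 gives > 5000 nM, which is a limit of the assay and not a number. Compound 2 `COc1ccc(S(=O)(=O)N2CCC(N3CCC(C)CC3)CC2)cc1OC` shares the core of compound 1. In this assay compound 2 gives > 5000 nM, again a limit and not a number. Compound 1 thus stands exactly where every value shown stands: the limit of > 5000 nM in this assay, at which 2 of the 2 values shown sit. Within the data shown here, no step between measured compounds can be drawn from two limits.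

Compound 3 `CCc1ccc(S(=O)(=O)N2CCC(N3CCC(C)CC3)CC2)cc1` is the next candidate for this assay. (ethyl in place of 2-fluorophenyl on an aromatic carbon). Nothing measured in the series supports a step in either direction beyond the usual scatter, as the shared core has so far returned only limits. Compound 3 is accordingly expected to give 8000 nM in this assay, with a range of 3000 nM to 30000 nM. That estimate means a step that the limit leaves unreadable from compound 1 to compound 3, which is expected to lie within the scatter. Most likely compound 3 again returns only a limit.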

Compound 3, half-maximal inhibitory concentration: > 5000 nM
Compound 3: only a limit was reported; the forecaster's own chance of this, stated with the estimate: 75%; the middle value does not contradict the limit.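

Among these compounds, compound 1 and compound 3 both return only a limit in this assay, so no step between them can be read. The compounds shown leave open whether 2-fluorophenyl or ethyl on the shared core makes any difference to this read-out, since the whole series rests at one limit: the limit of > 5000 nM in this assay, at which 3 of the 3 values shown sit.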